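The source may hold more compounds than are shown below. What is called first, only, known or untested is meant among the compounds shown, and "the series" means these compounds.

Working notes on the series.

Two compounds of the shared core carry a number in a functional assay on the whole organism (strain Swiss Albino) for inhibition, with Mus musculus as the target, read by paw edema, with a stated time of 270 min, at a dose of 100 mg/kg by the oral route; on this read-out higher numbers stand for more inhibition at the one dose given (going by the name of the read-out) and lower numbers for less inhibition. Compound 1, `CCCNC(=S)N1N=C(c2ccc(C)cc2)CC1c1ccc[nH]1`, in this assay gives 15.7%. Compound 2, `CCNC(=S)N1N=C(c2ccc(OC)cc2)CC1c1ccc[nH]1`, in this assay gives 18.9%. Compound 2 thus stands at the upper of the two numbers shown, but its distance from compound 1 is within the usual scatter, so the two measurements cannot be told apart. Among the measured compounds shown here, no pair of compounds measured so far differs in one place only: compound 1 and compound 2 differ both on the chain and on the aryl group, so no single step can be read from them.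

Compound 3, `CCCNC(=S)N1N=C(c2ccc(OC)cc2)CC1c1ccc[nH]1`, has not been measured in this assay. It differs from compound 2 by methyl in place of hydrogen on a saturated chain carbon, two bonds along the chain from an amide-type nitrogen.

For the measured compounds named here, with no counted step between measured compounds, nothing in the data points to a change beyond the scatter, and the step from compound 2 to compound 3 in this assay is expected to be small, a number 1.9 percentage points lower from compound 2 to compound 3 (within the scatter). Compound 3 in this assay is therefore estimated at 17%, with a range from 8% to 28%.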

Compound 3, a percentage reported as inhibition, in the whole organism at one dose (the size of the read-out at that dose, not a potency): 22.6%
Estimate against measurement, compound 3: 5.6 percentage points below; the range from low to high includes it.
By their numbers in this assay, from the lowest: compounds 1, 2 and 3 (each within the scatter of the next).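

The change from ethylamino to propylamino now has a reading of its own in this assay: with methoxy held on the aromatic carbon, the step is a number 3.7 percentage points higher from compound 2 to compound 3 (within the scatter) and cannot be told apart from no change at this position. The aromatic carbon can now be read as well, with the propylamino chain held: methoxy in place of methyl gives a number 6.9 percentage points higher from compound 1 to compound 3 (within the scatter) and so also cannot be told apart from no change, which leaves neither place with a step beyond the scatter at the one dose given. No measurement at hand bears on why these two steps come out as they do.

As far as these compounds go, whether a longer chain such as butyl, or a chain ending in an amine, would carry the number at this position beyond the scatter remains open. It is equally open whether a carboxylic acid or a chlorine atom on the aromatic carbon, in place of methoxy or methyl, would separate from the compounds shown.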